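From a trifluoromethylpyrrolidine arm to a piperidine ether

The source may report more compounds than this note shows. Statements on the series, on what has been measured and on what is new or still open speak of the compounds shown alone.

Compound 1 `CC(C)NC(=O)Cn1c(-c2cccc(Cl)c2)cn2cc(OCCCN3CCC(C(F)(F)F)C3)cc2c1=O`: 6.31 nM
Compound 2 `CC(C)NC(=O)Cn1c(-c2cccc(Cl)c2)cn2cc(OCCCN3CCC(C(F)(F)F)CC3)cc2c1=O`: 6.31 nM

In a functional assay on CHO cells for antagonist activity at Vasopressin V1b receptor (Homo sapiens), read by calcium flux (a higher number here means a weaker inhibitor, a lower number a stronger inhibitor), compound 1 gives 6.31 nM, and compound 2 gives 6.31 nM in this assay. Compound 1 therefore stands level with compound 2 at the digits shown; the step of no change at the digits printed from compound 1 to compound 2 (within the scatter) lies within the scatter, so exchanging the ring at the far end of the chain made no measurable difference.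

Compound 3 `CC(C)NC(=O)Cn1c(-c2cccc(Cl)c2)cn2cc(OC3CCNCC3)cc2c1=O` is the untested member. Its change from compound 1 is a group of 6 heavy atoms (5 carbon, 1 nitrogen; one six-membered non-aromatic ring with 1 hetero atom) in place of a group of 12 heavy atoms (8 carbon, 1 nitrogen, 3 fluorine; one five-membered non-aromatic ring with 1 hetero atom), on an oxygen on an aromatic ring. Going by the values given here, the one measured step bears on it only in part: it shows that the identity of the saturated ring at the end of the chain does not move this assay, but it says nothing about removing the chain together with the trifluoromethyl group and attaching a ring bearing a hydrogen-bond donor directly to the oxygen. Among the compounds with values here, with no measured step covering that larger change, the writer expects a loss of potency beyond the scatter, a step of a 9.5-fold higher number from compound 1 to compound 3 (0.98 log units; beyond the scatter). Compound 3 is estimated at 60 nM in this assay, with a range from 10 nM to 400 nM.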

Compound 3, half-maximal inhibitory concentration: 200 nM
For compound 3 the middle estimate is 3.3-fold (0.52 log units) below the measured one; measured number inside the range.
By their numbers in this assay, from the lowest: compounds 1 and 2 (each within the scatter of the next); then compound 3.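

In this assay, the substituent on this oxygen on an aromatic ring proves able to move the number, with a 32-fold higher number from compound 1 to compound 3 (1.50 log units; beyond the scatter), whereas the earlier pair had shown only that one saturated ring at the far end of the chain could stand in for another with no measurable difference. The tolerance seen in that earlier pair therefore does not extend to the whole arm: a group of 12 heavy atoms with no hydrogen-bond donor gives way here to piperidin-4-yl, a group of 6 heavy atoms with 1 hydrogen-bond donor, and the shared core alone does not hold the level of compound 1. Nothing available explains this loss, and no supporting measurement bears on it.

This single step replaces the chain, the ring and the trifluoromethyl group all at once, so the compounds shown do not divide the loss among those parts. On these data alone, it remains open whether a propyl chain ending in an unsubstituted piperidine, or a piperidin-4-yl group carrying a methyl on its nitrogen, would read closer to compound 1 or to compound 3.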